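The source may hold more compounds than are shown below. What is called first, only, known or untested is meant among the compounds shown, and "the series" means these compounds.

Working notes on a set of four compounds that share one core type, with the whole-animal read-out as the only measurement.

Compound 1 `CC1=C(C(=O)Nc2ccc(F)cc2)C(c2ccc([N+](=O)[O-])cc2)N=C(SCc2ccccc2)N1` is tested in a functional assay on the whole organism (artery, strain albino) with Rattus norvegicus as the target, with a stated time of 120 min, at a dose of 10 mg/kg by the oral route (a higher number here means more inhibition at the dose given (going by the name of the read-out), a lower number less inhibition), where compound 1 gives 18%. Compound 2 `CC1=C(C(=O)Nc2ccc(F)cc2)C(c2ccc([N+](=O)[O-])cc2)N=C(SCc2ccccc2Cl)N1` carries chloro in place of hydrogen on an aromatic carbon; in this assay compound 2 gives 8.8%, so that a number 9.2 percentage points lower from compound 1 to compound 2 (within the scatter). Compound 3 `CC1=C(C(=O)Nc2ccc([N+](=O)[O-])cc2)C(c2cccc([N+](=O)[O-])c2)N=C(SCc2ccccc2)N1` rests on a differently substituted core; the difference between the core of compound 3 and the core of compound 1 is not broken down here. In this assay compound 3 gives 10.3%. Compound 4 `CC1=C(C(=O)Nc2ccc([N+](=O)[O-])cc2)C(c2cccc([N+](=O)[O-])c2)N=C(SCc2ccccc2Cl)N1` stands to compound 3 as compound 2 stands to compound 1: chloro in place of hydrogen on an aromatic carbon, at the same place, on an aromatic carbon of a six-membered aromatic ring of carbon only, ortho to a large group. This change occurs twice in the set, and only once with a measured outcome. For compound 4 the step of a number 4.3 percentage points lower from compound 3 to compound 4 (within the scatter) is expected, smaller than the measured one because a number 9.2 percentage points lower from compound 1 to compound 2 (within the scatter) itself lies within the scatter and the two cores differ. Compound 4 is therefore estimated at 6%, with a range from -4% to 16%.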

Compound 4, a percentage reported as inhibition, in the whole organism at one dose (the size of the read-out at that dose, not a potency): 7.7%
Beside the measured number, compound 4's estimate is 1.7 percentage points below it; the measured number falls inside the stated range.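

In this assay, the change from benzylsulfanyl to (2-chlorobenzyl)sulfanyl on the second core gives a number 2.6 percentage points lower from compound 3 to compound 4 (within the scatter). Set beside the earlier case, the two steps do not differ: the same change on two cores in this assay, a number 9.2 percentage points lower (within the scatter) from compound 1 to compound 2 and a number 2.6 percentage points lower (within the scatter) from compound 3 to compound 4, 6.6 percentage points apart, within the scatter of two such steps. This shows that, across these two cores, the change gives steps that stay within the scatter and cannot be told apart, but with neither step beyond the scatter, it does not show that the chloro has any real effect on the read-out on either core, nor does a pair of cores establish that the step would carry to others.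

The compounds shown leave open whether a different group at the same place, such as methoxy or a dimethylamino group, would give a step beyond the scatter. Also open, on these data alone, is what a longer chain, such as phenethyl in place of benzyl, or a carboxylic acid in place of a nitro group would do to the read-out.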